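Compound 3 to compound 4 on the sulfonyl sulfur

The source may report more compounds than this note shows. Statements on the series, on what has been measured and on what is new or still open speak of the compounds shown alone.

Compound 1 `C[C@@H]1CN(S(=O)(=O)c2ccc(NC(=O)NCc3cccnc3)cc2)C[C@H](C)O1` gives 17 mL/min/kg
Compound 2 `O=C(NCc1cccnc1)Nc1ccc(S(=O)(=O)N2CC3(COC3)C2)cc1` gives 7 mL/min/kg
Compound 3 `O=C(NCc1cccnc1)Nc1ccc(S(=O)(=O)N2CCC3(CCNC3)CC2)cc1` gives 4 mL/min/kg

All three values come from an ADME assay on microsomes from liver (Homo sapiens) for pharmacokinetics, read by LC-MS, with a stated time of 60 min, tested at 1 uM (a lower number here means slower removal, a higher number faster removal of the compound), and compound 3 stands at 4 mL/min/kg in that set. Its nearest gap is a 1.8-fold lower number from compound 2 to compound 3 (0.24 log units; within the scatter) and its widest is a 4.3-fold lower number from compound 1 to compound 3 (0.63 log units; beyond the scatter) in the same measure. The change now followed is a group of 8 heavy atoms (6 carbon, 2 nitrogen; one seven-membered non-aromatic ring with 2 hetero atoms) in place of a group of 10 heavy atoms (8 carbon, 2 nitrogen; one five-membered non-aromatic ring with 1 hetero atom, one six-membered non-aromatic ring with 1 hetero atom), on a sulfonyl sulfur and it gives compound 4 `CC1CCN(S(=O)(=O)c2ccc(NC(=O)NCc3cccnc3)cc2)CCN1` as the product. Earlier swaps at this place bear on it, namely a 2.4-fold lower number from compound 1 to compound 2 (0.39 log units; beyond the scatter) and the two already named, none more than modest. Going by the values given here, no measured compound holds a seven-membered ring, so no step beyond the scatter is expected. The estimated step is a 1.3-fold higher number from compound 3 to compound 4 (0.10 log units; within the scatter) and so stays within it. Compound 4 is expected at 5 mL/min/kg within an estimated range from 3 mL/min/kg to 10 mL/min/kg as its likely span.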

Compound 4, clearance: 5 mL/min/kg
Compound 4: middle estimate and measured number agree at the digits printed, and the stated range covers the measured number.
By their numbers in this assay, from the lowest: compounds 3, 4 and 2 (each within the scatter of the next); then compound 1.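

The seven-membered ring with 2 hetero atoms on the sulfonyl sulfur adds a third ring type here, and in this assay it cannot be told apart from the two other groups: a 1.3-fold higher number from compound 3 to compound 4 (0.10 log units; within the scatter) and a 1.4-fold lower number from compound 2 to compound 4 (0.15 log units; within the scatter) both stay small. Against the group of compound 1, a 3.4-fold lower number from compound 1 to compound 4 (0.53 log units; beyond the scatter), so compound 1 now stands apart from three different groups at this place. Nothing at hand explains these numbers. As far as these compounds go, whether an open-chain amine or a ring carrying a carboxylic acid on the sulfonyl sulfur would stay with compound 2, compound 3 and compound 4 or with compound 1 remains open.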